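Compound 4 and the 3-chloro-2-fluorophenyl group

The source may hold more compounds than are shown below. What is called first, only, known or untested is meant among the compounds shown, and "the series" means these compounds.

Of the compounds shown here, three on a shared core have been measured in a functional assay on PC-3 cells (Homo sapiens) for antiproliferative activity, read by MTT assay, with a stated time of 48 h (a higher number here means a weaker inhibitor, a lower number a stronger inhibitor), so far. Compound 1 (`O=C(/C=C/c1ccc(O)cc1)Nc1cc2c(Nc3ccc(Cl)c(Cl)c3)ncnc2s1`) stands at 300 nM and compound 2 (`O=C(/C=C/c1ccccc1)Nc1cc2c(Nc3ccc(F)c(Cl)c3)ncnc2s1`) at 700 nM while compound 3 (`O=C(/C=C/c1ccccc1)Nc1cc2c(Nc3ccc(Cl)c(Cl)c3)ncnc2s1`) reads 480 nM as the middle of the three numbers. Both steps that reach compound 3 lie within the scatter.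

Compound 4 (`O=C(/C=C/c1ccccc1)Nc1cc2c(Nc3cccc(Cl)c3F)ncnc2s1`) is still unmeasured. It carries 3-chloro-2-fluorophenyl in place of 3,4-dichlorophenyl on a nitrogen on an aromatic ring. Two measured steps can be weighed against this change. The first, a 1.6-fold higher number from compound 1 to compound 3 (0.20 log units; within the scatter) for hydrogen in place of hydroxy, concerns a group that this change leaves untouched, so it bears on the question only slightly. The closer guide is a 1.5-fold lower number from compound 2 to compound 3 (0.16 log units; within the scatter) for chloro in place of fluoro on an aromatic carbon. Going by the values given here, compound 4 also trades a chloro for a fluoro, although no measured compound carries its 3-chloro-2-fluorophenyl group. A small move toward a higher number is therefore expected, not clearly beyond the scatter. The expected move is a 1.5-fold higher number from compound 3 to compound 4 (0.16 log units; within the scatter) in this assay as a rough guide. The estimate for compound 4 is 700 nM with an expected range of 280 nM to 1700 nM around it.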

Compound 4, half-maximal inhibitory concentration: 400 nM
Estimate against measurement, compound 4: 1.8-fold (0.24 log units) above, and the stated range covers the measured number.
By their numbers in this assay, from the lowest: compounds 1, 4, 3 and 2 (each within the scatter of the next, the first and the last beyond it).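

In this assay, 3-chloro-2-fluorophenyl in place of 3,4-dichlorophenyl on a nitrogen on an aromatic ring gives a 1.2-fold lower number from compound 3 to compound 4 (0.08 log units; within the scatter), and the same group in place of 3-chloro-4-fluorophenyl gives a 1.8-fold lower number from compound 2 to compound 4 (0.24 log units; within the scatter). The earlier compounds had shown only a swap of one halogen on this ring, whereas compound 4 changes the ring's substitution pattern as well, and its number still stays within the scatter of both compounds that differ from it at this place alone. Nothing measured in this set explains this result.

The compounds shown carry only chloro and fluoro on this phenyl ring, so they leave open whether the flat response at this position would hold for a methoxy group, an amine or a carboxylic acid there. They also leave open whether 3-chloro-2-fluorophenyl would read the same alongside the hydroxy group that compound 1 carries on its other aromatic ring, since that group has been seen here only with 3,4-dichlorophenyl.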